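The source may hold more compounds than are shown below. What is called first, only, known or untested is meant among the compounds shown, and "the series" means these compounds.

In a functional assay on HeLa cells (Homo sapiens) for inhibition, read by sulforhodamine B assay, with a stated time of 74 h (a higher number here means a weaker inhibitor, a lower number a stronger inhibitor), compound 1 (`CS(=O)(=O)N1C(=O)COC12C=CC(=O)C=C2`), with methyl on the sulfonyl sulfur, gives 7530 nM. Compound 2 (`O=C1C=CC2(C=C1)OCC(=O)N2S(=O)(=O)c1ccc(Cl)cc1`), with 4-chlorophenyl in that place, is recorded only as a limit of the assay, > 10000 nM. It therefore stands on the numbers as a limit and not as a measured value.

The change under consideration leads to compound 3 (`O=C1C=CC2(C=C1)OCC(=O)N2S(=O)(=O)c1ccc(Br)s1`): 5-bromothiophen-2-yl in place of 4-chlorophenyl on a sulfonyl sulfur. In words, 5-bromothiophen-2-yl takes the place of 4-chlorophenyl on a sulfonyl sulfur, whose other neighbour of note is an amide-type nitrogen in a ring.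

For the measured compounds named here, only one measured step bears on this position: an at least 1.3-fold higher number from compound 1 to compound 2 (0.12 log units; that floor lies within the scatter). That step replaces methyl rather than one ring with another, and it gives only a floor, so it sets no size for the new change. No step beyond the scatter can be expected with confidence in this assay, and compound 3 may also be reported only as a limit.

The estimated step is an at least 1.2-fold lower number from compound 2 to compound 3 (0.09 log units; that floor lies within the scatter). For compound 3 the expected value is 8000 nM, with an estimated range from 2500 nM to 25000 nM.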

Compound 3, half-maximal inhibitory concentration: 30 nM
The estimate for compound 3 lay 270-fold (2.43 log units) above the measured number, and the stated range ends above it.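

In this assay, 5-bromothiophen-2-yl in place of 4-chlorophenyl on a sulfonyl sulfur gives an at least 330-fold lower number from compound 2 to compound 3 (2.52 log units; beyond the scatter), so this position, for which the earlier pair offered only a floor within the scatter, can move the number strongly. Against methyl on the same sulfur, the 5-bromothiophen-2-yl group gives a 250-fold lower number from compound 1 to compound 3 (2.40 log units; beyond the scatter), a step between two measured numbers, so the size of the change does not rest on a limit alone. Compound 2 stands only as a limit, so its step to the new group is a floor and not a size: the limit of > 10000 nM in this assay, at which 1 of the 3 values shown sits.

The compounds shown do not separate the five-membered aromatic ring from its bromine: a 4-bromophenyl group, a 5-chlorothiophen-2-yl group or an unsubstituted thiophen-2-yl group would show which part of the change carries the step. They also leave open how the number responds to an amine or a carboxylic acid on that ring, or to a longer alkyl chain in place of methyl on the sulfonyl sulfur.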